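This account rests on a few compounds, and the source may have more. Where it says the series, first, only, none or still open, it means among the compounds named here.

Values in a physicochemical assay for lipophilicity (on this read-out lower numbers stand for lower lipophilicity and higher numbers for higher lipophilicity), so far:
compound 1 `CCCC(CCC)C(=O)OCC1(CO)C/C(=C/c2ccncc2)C(=O)O1` gives 2.9
compound 2 `CN(C)c1ccc(C(=O)OCC2(CO)C/C(=C\c3ccc4ccccc4n3)C(=O)O2)cc1` gives 3.22
compound 3 `CN(C)c1ccc(C(=O)OCC2(CO)C/C(=C/c3ccncc3)C(=O)O2)cc1` gives 2.07

Compound 1 is second highest of the three, with compound 2 higher and compound 3 lowest. Compound 4 `CCCC(CCC)C(=O)OCC1(CO)C/C(=C\c2ccncc2)C(=O)O1` is still unmeasured. The change from compound 1 is the two compounds have the same atoms and bonds; at least one stereo element is drawn with a configuration in one of them and without one in the other: 1 of 2 stereo elements differ; a double bond is drawn Z in compound 1 and E in compound 4, with a double bond drawn Z in compound 1 and E in compound 4. Within the data shown here, the one measured step, a number 0.83 log units lower from compound 1 to compound 3 (beyond the scatter), exchanges a group and leaves that double bond as drawn, so it gives no size for this change. Among the measured compounds shown here, no measured step isolates the double bond. The expected no change at the digits printed from compound 1 to compound 4 (within the scatter) therefore stays within the scatter, with no direction favoured. The estimate for compound 4 is 2.9, with an expected range of 2.5 to 3.3.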

Compound 4, partition coefficient: 2.9
Beside the measured number, compound 4's estimate shows no gap at the digits printed, and the stated range covers the measured number.
By their numbers in this assay, from the lowest: compound 3; then compounds 1 and 4 (each within the scatter of the next); then compound 2.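

In this assay, drawing the double bond E rather than Z gives no change at the digits printed from compound 1 to compound 4 (within the scatter). Among these compounds, this is the first step that isolates this double bond, since the earlier step exchanged a group on a carbonyl carbon and left it as drawn. With 1-propylbutyl on the carbonyl carbon, the drawn geometry does not separate the pair, with one caution on the reading: the fact that one of compounds 1 and 4 is drawn with a defined configuration and the other without, at the place where they differ

As far as these compounds go, whether the same holds with 4-(dimethylamino)phenyl, a longer chain or a carboxylic acid at that carbonyl carbon stays open.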